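The source may hold more compounds than are shown below. What is called first, only, known or untested is meant among the compounds shown, and "the series" means these compounds.

The measured compounds:
- compound 1, `COc1cccc(CNCCCNc2ccnc3cc(Oc4ccc(F)cc4)ccc23)c1O`, gives 14500 nM in a physicochemical assay for solubility, with a stated time of 18 h, at pH 7.4; a higher number here means a more soluble compound, a lower number a less soluble compound
- compound 2, `COc1cccc(CNCCCNc2ccnc3cc(-c4ccc(C(F)(F)F)cc4)ccc23)c1O`, gives 32000 nM in this assay
- compound 3, `Fc1ccc(Oc2ccc3c(NCCCNCc4ccco4)ccnc3c2)cc1`, gives 14500 nM in this assay

Compound 3 stands level with compound 1 at the digits shown, and together the two hold the lowest numbers of the three: the step of no change at the digits printed from compound 1 to compound 3 (within the scatter). For the measured compounds named here, no step is computed between compound 3 and compound 2, but their two values show compound 2 with the higher number.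

Compound 4, `FC(F)(F)c1ccc(-c2ccc3c(NCCCNCc4ccco4)ccnc3c2)cc1`, differs from compound 3 in one place: 4-(trifluoromethyl)phenyl in place of 4-fluorophenoxy on an aromatic carbon. One measured step carries this same change, 4-(trifluoromethyl)phenyl in place of 4-fluorophenoxy on an aromatic carbon, on the core of compound 1: a 2.2-fold higher number from compound 1 to compound 2 (0.34 log units; beyond the scatter), a modest rise beyond the scatter. Compound 1 and compound 3 differ only at the chain end, and no change at the digits printed from compound 1 to compound 3 (within the scatter) shows that this difference left the number untouched, so the rise seen from compound 1 to compound 2 is expected to carry over to the pair of compound 3 and compound 4.

In this assay the step from compound 3 to compound 4 is therefore expected to be a 2.2-fold higher number from compound 3 to compound 4 (0.34 log units; beyond the scatter). Compound 4 is estimated at 32000 nM, with a range of 15000 nM to 68000 nM.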

Compound 4, solubility: 32000 nM
The estimate for compound 4 equals the measured number at the digits printed, within the range that was stated.
By their numbers in this assay, from the lowest: compounds 1 and 3 (each within the scatter of the next); then compounds 2 and 4 (each within the scatter of the next).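

In this assay the change from 4-fluorophenoxy to 4-(trifluoromethyl)phenyl on this aromatic carbon can now be read with two different chain ends: with the furan-2-yl end it gives a 2.2-fold higher number from compound 3 to compound 4 (0.34 log units; beyond the scatter) and with the 2-hydroxy-3-methoxyphenyl end it gave a 2.2-fold higher number from compound 1 to compound 2 (0.34 log units; beyond the scatter) in the same measure. For the compounds shown here, the exchange of chain ends, earlier seen only with 4-fluorophenoxy in place, also leaves the number level with 4-(trifluoromethyl)phenyl in place, as the pair read as no change at the digits printed from compound 2 to compound 4 (within the scatter) shows. Across these four compounds, the number therefore follows the group on the aromatic carbon and not the chain end, and nothing offered here explains that rise.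

From the compounds shown here alone, it remains open whether the rise belongs to the trifluoromethyl group or to the loss of the ether oxygen, which a plain phenyl or a phenoxy ring carrying trifluoromethyl could separate. Going by these compounds, how far the independence of the two sites extends also stays open, for instance with a longer chain between the two amine nitrogens or with a carboxylic acid at the chain end.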